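The compounds below may be only part of what the source reports. "The series", "measured", "known", "first", "only" and "open" are said of these compounds alone.

Compound 1 `CCC(=O)N1CCc2nc(C#Cc3ccccc3)sc2C1` carries an ethyl group on its carbonyl carbon, and in an assay on HEK293 cells for negative allosteric modulation of metabotropic glutamate receptor 5 (Homo sapiens), read by FLIPR, with a stated time of 1 h (a lower number here means a stronger inhibitor, a higher number a weaker inhibitor), compound 1 gives 38 nM. Compound 2 `CC1CC(C(=O)N2CCc3nc(C#Cc4ccccc4)sc3C2)C1` gives in this assay > 10000 nM, which is a limit of the assay rather than a number. Compound 3 `O=C(C1CC(F)C1)N1CCc2nc(C#Cc3ccccc3)sc2C1` gives in this assay > 10000 nM, again only a limit. Compound 3 thus stands at the limit, where one further value also sits; the steps of an at least 260-fold higher number from compound 1 to compound 2 (2.42 log units; beyond the scatter) and an at least 260-fold higher number from compound 1 to compound 3 (2.42 log units; beyond the scatter) were both large, while a step that the two limits leave unreadable from compound 2 to compound 3. Compound 4 `O=C(C1CCCO1)N1CCc2nc(C#Cc3ccccc3)sc2C1` differs from compound 3 by oxolan-2-yl in place of 3-fluorocyclobutyl on a carbonyl carbon. Within the data shown here, no measured step matches this change; both ring-for-ethyl steps reached the limit (the limit of > 10000 nM in this assay, at which 2 of the 3 values shown sit), so a ring of similar size is expected to keep the number high, and an at least 1.2-fold lower number from compound 3 to compound 4 (0.09 log units; that floor lies within the scatter) is expected. Compound 4 is therefore estimated at 8000 nM, within 1000 nM to 30000 nM.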

Compound 4, half-maximal inhibitory concentration: > 10000 nM
Compound 4 was reported as a limit; the forecaster's own chance of this, stated with the estimate: 60%; middle value at least 1.2-fold (0.09 log units) away from the limit.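

Replacing ethyl with oxolan-2-yl on the carbonyl carbon gives an at least 260-fold higher number from compound 1 to compound 4 (2.42 log units; beyond the scatter). The loss seen so far with carbon-only rings carrying methyl or fluoro therefore also occurs with a ring that holds an oxygen atom and a hydrogen-bond acceptor. The steps among compound 2, compound 3 and compound 4 cannot be read, so these three rings cannot be ranked: the limit of > 10000 nM in this assay, at which 3 of the 4 values shown sit.

The compounds shown leave open whether a longer chain such as propyl, or a smaller ring such as cyclopropyl, would keep the inhibition that compound 1 shows at 38 nM. They also leave open what an amine on this carbonyl carbon would do.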